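The source may hold more compounds than are shown below. What is called first, only, known or untested is meant among the compounds shown, and "the series" means these compounds.

Compound 1 `NC1=NC2(CCSCC2)N(OCCCOc2ccc(Cl)c(Cl)c2)C(N)=N1` is recorded as "not determined" (no result reported) in an assay on isolated protein for inhibition of Dihydrofolate reductase (Homo sapiens), read by spectrophotometry, using NADPH, with stated times of 5 s and 6 min (on this read-out higher numbers stand for weaker inhibition and lower numbers for stronger inhibition), so its standing rests only on its relatives. Compound 2 `NC1=NC2(CCOCC2)N(OCCCOc2ccc(Cl)cc2Cl)C(N)=N1` gives 7.46 nM in this assay, and compound 3 `NC1=NC2(CCOCC2)N(OCCCOc2ccc(Cl)c(Cl)c2)C(N)=N1` gives 8.23 nM. Within the data shown here, the one measured step, a 1.1-fold higher number from compound 2 to compound 3 (0.04 log units; within the scatter), shows that moving the two chloro groups about the ring leaves the read-out essentially unchanged. Compound 4 `NC1=NC2(CCSCC2)N(OCCCOc2ccc(Cl)cc2)C(N)=N1` differs from compound 1 by hydrogen in place of chloro on an aromatic carbon. No measured step removes a chloro group, so nothing shown bears directly on this change; the values of compound 2 and compound 3 only place the shared core near a single-digit nanomolar level. Compound 4 is therefore expected to give about 15 nM in this assay, within a range of 5 nM to 50 nM.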

Compound 4, half-maximal inhibitory concentration: 18.3 nM
Estimate against measurement, compound 4: 1.2-fold (0.09 log units) below; measured number inside the range.
By their numbers in this assay, from the lowest: compounds 2 and 3 (each within the scatter of the next); then compound 4.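

In this assay, among these compounds, compound 1 is recorded as "not determined" (no result reported) and is the only relative differing from compound 4 in one place, so no new step can be read. On these data alone, what that chloro group contributes stays open, and no evidence here bears on it.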